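This account rests on a few compounds, and the source may have more. Where it says the series, first, only, none or still open, it means among the compounds named here.

Compound 1 `O=S(=O)(NCCCNCc1ccccc1Cl)c1cc(C(F)(F)F)cc(C(F)(F)F)c1` carries a sulfonamide whose chain ends in a (2-chlorobenzyl)amino group. In a functional assay on A2780 cells (Homo sapiens) for inhibition, read by MTT assay, with a stated time of 72 h (a higher number here means a weaker inhibitor of growth, a lower number a stronger inhibitor of growth), compound 1 gives 9300 nM, the highest of the three numbers measured. Compound 2 `O=S(=O)(NCCCCNCc1ccc(Br)cc1)c1cc(C(F)(F)F)cc(C(F)(F)F)c1` gives 2100 nM in this assay, and compound 3 `COc1ccc(CNCCCNS(=O)(=O)c2cc(C(F)(F)F)cc(C(F)(F)F)c2)cc1` gives 1700 nM. The step of a 4.4-fold lower number from compound 1 to compound 2 (0.65 log units; beyond the scatter) and the step of a 5.5-fold lower number from compound 1 to compound 3 (0.74 log units; beyond the scatter) both lead away from compound 1 to a lower number, while the step of a 1.2-fold lower number from compound 2 to compound 3 (0.09 log units; within the scatter) stays within the scatter.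

Compound 4 `O=S(=O)(NCCCNCc1cccc(Cl)c1)c1cc(C(F)(F)F)cc(C(F)(F)F)c1` differs from compound 1 in one place: 3-chlorophenyl in place of 2-chlorophenyl on a saturated chain carbon bound to an amine nitrogen. Among the measured compounds shown here, no measured step moves the chlorine alone. The two steps from compound 1 both exchange the whole 2-chlorobenzyl group for another, a (4-bromobenzyl)amino or a 4-methoxyphenyl group, and in one of them the entering group is ((4-bromobenzyl)amino)methyl. They suggest that leaving the 2-chlorophenyl pattern can bring a modest drop in the number, but they do not isolate the position of the chlorine. A smaller step than either, toward a lower number, is therefore expected for compound 4, a 2.1-fold lower number from compound 1 to compound 4 (0.32 log units; beyond the scatter). The estimate for compound 4 in this assay is 4500 nM, with a range from 1500 nM to 12000 nM.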

Compound 4, concentration for 50% growth inhibition: 2200 nM
The estimate for compound 4 lay 2.0-fold (0.31 log units) above the measured number, and the stated range covers the measured number.
By their numbers in this assay, from the lowest: compounds 3, 2 and 4 (each within the scatter of the next); then compound 1.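

Moving the chlorine alone, with 3-chlorophenyl in place of 2-chlorophenyl on a saturated chain carbon bound to an amine nitrogen, gives a 4.2-fold lower number from compound 1 to compound 4 (0.63 log units; beyond the scatter) in this assay. The two compounds have the same atoms, joined differently, so this step shows what the earlier exchanges of whole groups could not: the position of the chlorine by itself is enough to shift the number beyond the scatter. Compound 4 also cannot be told apart from the other two compounds, with a 1.3-fold higher number from compound 3 to compound 4 (0.11 log units; within the scatter) and a 1.0-fold higher number from compound 2 to compound 4 (0.02 log units; within the scatter), which leaves compound 1, with its 2-chlorophenyl group, as the only one of the four that stands apart, and no measurement here explains why.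

The compounds shown leave open whether 4-chlorophenyl on the same chain would match compound 4, and whether an unsubstituted phenyl would sit with compound 1 or with the other three. They also leave open whether 2-fluorophenyl or 2-methoxyphenyl would raise the number as 2-chlorophenyl does, which would show whether this position matters for groups other than chlorine.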